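This account rests on a few compounds, and the source may have more. Where it says the series, first, only, none or still open, it means among the compounds named here.

Going by the values given here, compound 2, `C/C(=C\COC(=O)NC1CCCCC1)C1=CC(=O)C(C)(C)O1`, is one of two compounds measured in a functional assay on MT4 cells (Homo sapiens) for inhibition; a higher number here means a weaker inhibitor, a lower number a stronger inhibitor. In this assay compound 2 gives 2.4 ug/mL. Among the compounds with values here, its only measured neighbour is compound 1, `C/C(=C\COC(=O)NC(C)(C)C)C1=CC(=O)C(C)(C)O1`, which carries a tert-butyl group in place of the cyclohexyl group on the amide-type nitrogen; in this assay compound 1 gives 2.1 ug/mL. Within the data shown here, the step of a 1.1-fold higher number from compound 1 to compound 2 (0.06 log units; within the scatter) is the single comparison available, and it is too small to separate the two compounds.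

Compound 3, `C/C(=C\COC(=O)NCc1ccccc1)C1=CC(=O)C(C)(C)O1`, is not yet measured. It differs from compound 2 in one place: benzyl in place of cyclohexyl on an amide-type nitrogen. Among the measured compounds shown here, only the step from compound 1 to compound 2 bears on this change, since it is the one measured exchange at the same nitrogen, and it stayed within the scatter. On that basis no step beyond the scatter is expected for compound 3, and the expected step of a 1.0-fold higher number from compound 2 to compound 3 (0.02 log units; within the scatter) is small. Compound 3 is therefore estimated at 2.5 ug/mL in this assay, with a range from 1.2 ug/mL to 5.5 ug/mL that allows for the usual spread of repeated measurements.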

Compound 3, half-maximal inhibitory concentration: 2 ug/mL
Estimate against measurement, compound 3: 1.3-fold (0.10 log units) above; the range from low to high includes it.
By their numbers in this assay, from the lowest: compounds 3, 1 and 2 (each within the scatter of the next).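

Going by these compounds alone, until now, this amide-type nitrogen had been seen only with tert-butyl and cyclohexyl, so an aromatic ring at this place had not been tested. In this assay the exchange of cyclohexyl for benzyl gives a 1.2-fold lower number from compound 2 to compound 3 (0.08 log units; within the scatter) and the exchange of tert-butyl for benzyl gives a 1.1-fold lower number from compound 1 to compound 3 (0.02 log units; within the scatter) on the same nitrogen. An aromatic ring of carbon can therefore take the place of a non-aromatic one here without the number leaving the scatter, and tert-butyl, cyclohexyl and benzyl cannot be told apart in this read-out, though nothing available accounts for this.

The compounds shown leave open whether any group on this nitrogen can move the number beyond the scatter, for instance an amine, a carboxylic acid or a longer chain, or a benzyl ring carrying a nitrile or a fluorine. The shared core is the same in all three compounds, so they also leave open how much the number depends on the core rather than on the group at this nitrogen.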